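Replacing a Chloromethyl Arm with a Bromohydrin Chain

The source may hold more compounds than are shown below. What is called first, only, known or untested is meant among the compounds shown, and "the series" means these compounds.

Measured so far:
Compound 1 `CC[C@H](c1ccc(O)cc1)[C@@H](CC)c1ccc(CCl)cc1`: 1.3 h
Compound 2 `CC[C@H](c1ccc(O)cc1)[C@@H](CC)c1ccc(OCC(=O)CCl)cc1`: 0.25 h

In an ADME assay for pharmacokinetics (on this read-out higher numbers stand for a longer-lived compound and lower numbers for a shorter-lived compound), compound 1 gives 1.3 h, the highest of the two numbers seen. Compound 2 gives 0.25 h in this assay. For the measured compounds named here, the one step measured, a 5.2-fold lower number from compound 1 to compound 2 (0.72 log units; beyond the scatter), comes from swapping the chloromethyl group for ((chloromethyl)carbonyl)methoxy on an aromatic carbon.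

Compound 3 `CC[C@H](c1ccc(O)cc1)[C@@H](CC)c1ccc(OCC(O)CBr)cc1` is not yet measured. It differs from compound 1 in one place: 3-bromo-2-hydroxypropoxy in place of chloromethyl on an aromatic carbon. Like compound 2, it carries a longer side chain attached through oxygen where compound 1 has chloromethyl, so the measured step is the closest guide. That step was modest and downward, and a similar step is expected here, because a 5.2-fold lower number from compound 1 to compound 2 (0.72 log units; beyond the scatter) points to a shorter-lived compound once the chloromethyl group is replaced in this way. Compound 3 is therefore estimated at 0.4 h, with a range from 0.15 h to 1 h, the expected step being a 3.3-fold lower number from compound 1 to compound 3 (0.51 log units; beyond the scatter).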

Compound 3, half-life: 0.5 h
Beside the measured number, compound 3's estimate is 1.3-fold (0.10 log units) below it, within the range that was stated.
By their numbers in this assay, from the lowest: compounds 2 and 3 (each within the scatter of the next); then compound 1.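

In this assay, a second side chain attached through oxygen, on an aromatic carbon para to a large group, also gives a lower number than chloromethyl: a 2.6-fold lower number from compound 1 to compound 3 (0.41 log units; beyond the scatter), so the earlier drop is no longer a lone case. Changing the (chloromethyl)carbonyl of compound 2 to the 2-bromo-1-hydroxyethyl of compound 3 alters the carbonyl and the halogen together, yet gives only a 2.0-fold higher number from compound 2 to compound 3 (0.30 log units; within the scatter), so these two chains cannot be told apart on this read-out. No measurement at hand offers a reason for the lower numbers of these chains.

Still open, on these data alone, is which feature of the chains goes with the drop: the oxygen link, the chain itself or the halogen. Also open, as far as these compounds go, is how a plain propoxy chain, or one ending in an amine or a carboxylic acid, would compare with compound 1.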